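Longer acyl chain on the ring nitrogen: stepping toward an octyl

The source may report more compounds than this note shows. Statements on the series, on what has been measured and on what is new or still open speak of the compounds shown alone.

Compound 1, `CC(=O)N1c2ccccc2CCC1C(=O)Nc1cc(C(F)(F)F)cc(C(F)(F)F)c1` — > 70000 nM
Compound 2, `CCCC(=O)N1c2ccccc2CCC1C(=O)Nc1cc(C(F)(F)F)cc(C(F)(F)F)c1` — 15000 nM
Compound 3, `O=C(Nc1cc(C(F)(F)F)cc(C(F)(F)F)c1)C1CCc2ccccc2N1C(=O)c1ccc(Cl)cc1` — 889 nM

In a functional assay on NCI-H23 cells (Homo sapiens) for cytotoxicity, read by sulforhodamine B assay, with a stated time of 72 h (a lower number here means a stronger inhibitor of growth, a higher number a weaker inhibitor of growth), compound 1 gives only a limit, not a number; the limit of > 70000 nM in this assay, at which 1 of the 3 values shown sits, marks that boundary. Compound 3 stands lowest of the two real numbers, with compound 2 nearest at a 17-fold lower number from compound 2 to compound 3 (1.23 log units; beyond the scatter). Compound 4, `CCCCCCCCC(=O)N1c2ccccc2CCC1C(=O)Nc1cc(C(F)(F)F)cc(C(F)(F)F)c1`, has not yet been measured. It differs from compound 3 in one place: octyl in place of 4-chlorophenyl on a carbonyl carbon.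

Going by the values given here, two measured steps bear on this change. Lengthening the acyl chain gave an at least 4.6-fold lower number from compound 1 to compound 2 (0.66 log units; beyond the scatter), while swapping a short chain for the aromatic ring gave an at least 78-fold lower number from compound 1 to compound 3 (1.89 log units; beyond the scatter) and a 17-fold lower number from compound 2 to compound 3 (1.23 log units; beyond the scatter). The octyl chain of compound 4 continues the lengthening seen from compound 1 to compound 2, so its number is expected to fall below that of compound 2, yet the two chain-to-ring steps suggest it will not reach compound 3. The step of a 4.5-fold higher number from compound 3 to compound 4 (0.65 log units; beyond the scatter) is therefore expected. Compound 4 is estimated at 4000 nM, within 800 nM to 20000 nM.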

Compound 4, concentration for 50% growth inhibition: 3230 nM
Estimate against measurement, compound 4: 1.2-fold (0.09 log units) above, within the range that was stated.
By their numbers in this assay, from the lowest: compound 3; then compound 4; then compound 2. At a limit, above all of these: compound 1.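

Lengthening the chain on this carbonyl carbon beyond propyl still lowers the number in this assay, with a 4.6-fold lower number from compound 2 to compound 4 (0.67 log units; beyond the scatter) and an at least 21-fold lower number from compound 1 to compound 4 (1.33 log units; beyond the scatter), so a compound without a ring at this position can also inhibit growth. The aromatic ring keeps an edge over this long chain, however, with a 3.6-fold higher number from compound 3 to compound 4 (0.56 log units; beyond the scatter). Compound 1 gives only a limit, so the larger of the two chain steps is a bound and not a size: the limit of > 70000 nM in this assay, at which 1 of the 4 values shown sits.

The compounds shown leave open whether a chain longer than octyl would lower the number further or raise it again, and whether a chain carrying an amine would do as well. They also leave open whether the edge of 4-chlorophenyl comes from its ring or its chlorine, which plain phenyl could separate.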